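Triazole substituent changes on the shared core, cytotoxicity

The source may report more compounds than this note shows. Statements on the series, on what has been measured and on what is new or still open speak of the compounds shown alone.

Measured compounds:
- compound 1, `CCCCCCCCc1cn(C(c2ccccc2)c2cc3cc(Br)ccc3nc2OC)nn1`: 0.1%
- compound 2, `COc1nc2ccc(Br)cc2cc1C(c1ccccc1)n1cc(CCCO)nn1`: 11.3%
- compound 3, `COc1nc2ccc(Br)cc2cc1C(c1ccccc1)n1cc(-c2ccc(OC(F)(F)F)cc2)nn1`: -2.24%

In an ADME assay on HeLa cells (Homo sapiens) for cytotoxicity, read by sulforhodamine B assay, with a stated time of 48 h, tested at 10 uM (on this read-out higher numbers stand for more inhibition at the one concentration tested (going by the name of the read-out) and lower numbers for less inhibition), compound 3 stands lowest of the three, close to compound 1 but separated from compound 2 beyond the scatter. Compound 4, `COc1nc2ccc(Br)cc2cc1C(c1ccccc1)n1cc(CCCCCO)nn1`, is not yet measured. Its change from compound 3 is 5-hydroxypentyl in place of 4-(trifluoromethoxy)phenyl on an aromatic carbon. Among the measured compounds shown here, two steps bear on it: a number 13.5 percentage points lower from compound 2 to compound 3 (beyond the scatter) and a number 2.3 percentage points lower from compound 1 to compound 3 (within the scatter). The 5-hydroxypentyl chain sits between 3-hydroxypropyl and octyl in length and carries the same hydroxy as 3-hydroxypropyl, so a modest rise from compound 3 is expected, smaller than the reverse of the step from compound 2. The step expected is a number 8.2 percentage points higher from compound 3 to compound 4 (within the scatter). Compound 4 is estimated at 6%, within -5% to 17%.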

Compound 4, a percentage reported as inhibition, at one concentration (the size of the read-out at that concentration, not a potency): 1.08%
Compound 4: middle estimate off by 4.9 percentage points, on the high side; the range from low to high includes it.
By their numbers in this assay, from the lowest: compounds 3, 1 and 4 (each within the scatter of the next); then compound 2.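

In this assay, 5-hydroxypentyl in place of 4-(trifluoromethoxy)phenyl gives (a number 3.3 percentage points higher from compound 3 to compound 4 (within the scatter)), and compound 4 also stays level with the octyl chain of compound 1 (a number 1 percentage points higher from compound 1 to compound 4 (within the scatter)). With the hydroxy kept and only the chain changed, the reading separates (a number 10.2 percentage points lower from compound 2 to compound 4 (beyond the scatter)), so at this position the hydroxy alone does not carry the higher number of compound 2. No data here give a reason for this. On these data alone, whether the reading of compound 2 depends on chain length or on the hydroxy itself stays open. A 3-aminopropyl group or a 2-hydroxyethyl chain on the shared core would bear on that.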